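This account rests on a few compounds, and the source may have more. Where it says the series, first, only, none or still open, it means among the compounds named here.

Working notes on the series, read in a functional assay on HepG2 cells (Homo sapiens) for antiproliferative activity, read by XTT assay, with a stated time of 72 h; a higher number here means a weaker inhibitor, a lower number a stronger inhibitor. Within the data shown here, compound 1 (`CNc1ncnc2c1c(-c1ccco1)cn2[C@@H]1O[C@H](CO)[C@@H](O)[C@H]1O`) gives 850 nM, the only true number so far. Compound 2 (`COc1nc(N)nc2c1c(-c1cc3ccccc3o1)cn2[C@@H]1O[C@H](CO)[C@@H](O)[C@H]1O`) reads > 20000 nM, which is a limit of the assay and not a number. Compound 3 (`Nc1nc2c(c(-c3ccco3)cn2[C@@H]2O[C@H](CO)[C@@H](O)[C@H]2O)c(=O)[nH]1`) reads > 20000 nM, which is also a limit. That places compound 3 at the limit of > 20000 nM in this assay, at which 2 of the 3 values shown sit, so its actual position is not known.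

Compound 4 (`Nc1nc2c(c(-c3cccs3)cn2[C@@H]2O[C@H](CO)[C@@H](O)[C@H]2O)c(=O)[nH]1`) carries thiophen-2-yl in place of furan-2-yl on an aromatic carbon. Among the measured compounds shown here, no measured pair isolates this exchange, so what follows is expectation only. The starting point for that expectation is compound 3 at > 20000 nM, a limit. The expected step is a number no higher from compound 3 to compound 4 (the limit leaves the size open), nothing beyond the scatter of this assay and with no direction favoured. For compound 4 the estimate is 20000 nM, with an expected range from 6000 nM to 30000 nM. A reading that is again only a limit is the likelier outcome.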

Compound 4, half-maximal inhibitory concentration: > 20000 nM
Compound 4 gave a limit, no number; the forecaster's own chance of this, stated with the estimate: 70%; the middle value lies on the limit itself.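

In this assay compound 4 gives > 20000 nM, a limit and not a number. Compound 3 also stands at a limit, so no step can be read between compound 3 and compound 4. On these data alone, whether thiophen-2-yl and furan-2-yl differ at all in this assay stays open.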